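Amino in place of hydrogen on the anilino ring

The source may hold more compounds than are shown below. What is called first, only, known or untested is meant among the compounds shown, and "the series" means these compounds.

Compound 1 `Fc1cccc(-c2nc(Nc3ccccc3)c3cc(F)ccc3n2)c1` is the reference point of the set. Among the compounds with values here, in a functional assay on HT29-AK cells (Homo sapiens) for cytotoxicity, read by MTT assay, with a stated time of 48 h (a lower number here means a stronger inhibitor, a higher number a weaker inhibitor), compound 1 gives 48300 nM, the only number recorded so far. Compound 2 `Fc1cccc(-c2nc(Nc3cccc(Cl)c3)c3cc(F)ccc3n2)c1` carries chloro in place of hydrogen on an aromatic carbon; in this assay compound 2 returns > 50000 nM, which is a limit of the assay and not a number (the limit of > 50000 nM in this assay, at which 1 of the 2 values shown sits). The step of an at least 1.0-fold higher number from compound 1 to compound 2 (0.01 log units; that floor lies within the scatter) therefore has only a floor, and that floor lies within the scatter.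

Compound 3 `Nc1cccc(Nc2nc(-c3cccc(F)c3)nc3ccc(F)cc23)c1` differs from compound 1 in one place: amino in place of hydrogen on an aromatic carbon. Within the data shown here, the sole measured step at an aromatic carbon of this ring is the one from compound 1 to compound 2, and it shows nothing beyond the scatter. For compound 3 the expected step is a 1.1-fold lower number from compound 1 to compound 3 (0.03 log units; within the scatter), that is, none beyond the scatter. Compound 3 is estimated at 45000 nM, with a range from 15000 nM to 150000 nM.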

Compound 3, half-maximal inhibitory concentration: > 50000 nM
Compound 3 gave a limit, no number (the forecaster's own chance of this, stated with the estimate: 40%); middle value at least 1.1-fold (0.04 log units) away from the limit.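

Amino on the anilino ring, like chloro before it, ends at a limit of the assay in this assay, so two different groups on this ring now give no number. Within the data shown here, the only change available is an at least 1.0-fold higher number from compound 1 to compound 3 (0.01 log units; that floor lies within the scatter), so amino shows no measurable gain over hydrogen. The step between compound 2 and compound 3 cannot be read, so amino and chloro cannot be ranked against each other, and the series has little room left to show a weakening: the limit of > 50000 nM in this assay, at which 2 of the 3 values shown sit.

On these data alone, whether a hydroxyl, a methoxy or a carboxylic acid on this ring would give a number rather than a limit stays open. As far as these compounds go, how far compound 2 and compound 3 actually lie past the limit also stays open.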